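A few compounds are considered here, and "the series" means these few. Any claim that something is new, unique, unknown or untested is made for them only; others in the source may bear on it.

Compound 1 `CCCCCCCc1cc2cn([C@H]3C[C@H](O)[C@@H](CO)O3)c(=O)nc2o1`: in a functional assay on HEL cells (Homo sapiens) for cytotoxicity (on this read-out lower numbers stand for higher toxicity in this test and higher numbers for lower toxicity in this test), compound 1 gives only the assay limit of > 50000 nM.
Compound 2 `C=CCCCCc1cc2cn([C@H]3C[C@H](O)[C@@H](CO)O3)c(=O)nc2o1`: in this assay compound 2 likewise gives only the limit > 200000 nM.
Compound 3 `C=CCCCCCCCCc1cc2cn([C@H]3C[C@H](O)[C@@H](CO)O3)c(=O)nc2o1`: in this assay compound 3 also sits at the limit > 200000 nM.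

Compound 3 therefore stands at a limit, and the two other values shown are limits as well (the limit of > 200000 nM in this assay, at which 2 of the 3 values shown sit, (the limit of > 50000 nM in this assay, at which 1 of the 3 values shown sits)). The unmeasured compound 4 `C#CCCCCCCc1cc2cn([C@H]3C[C@H](O)[C@@H](CO)O3)c(=O)nc2o1` differs from compound 3 by ethynyl in place of but-3-en-1-yl on a saturated chain carbon, six bonds along the chain from an aromatic carbon. The measured steps that would bear on this change, a step that the two limits leave unreadable from compound 1 to compound 2, a step that the two limits leave unreadable from compound 1 to compound 3 and a step that the two limits leave unreadable from compound 2 to compound 3, are all left unreadable by the two limits, so neither a size nor a direction can be taken from them. Compound 4 is consequently expected to show no step beyond the scatter in this assay, with a number no higher from compound 3 to compound 4 (the limit leaves the size open). Compound 4 is estimated at 200000 nM, within 50000 nM to 400000 nM, most probably again reported only as a limit.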

Compound 4, half-maximal cytotoxic concentration: > 200000 nM
Compound 4: only a limit was reported (the forecaster's own chance of this, stated with the estimate: 85%); the middle value lies on the limit itself.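

In this assay compound 4 gives only the limit > 200000 nM, and its steps from compound 1, compound 2 and compound 3 cannot be read. The compounds shown leave open whether these chains differ at all on this read-out.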